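A few compounds are considered here, and "the series" means these few. Any claim that something is new, unique, unknown or untested is made for them only; others in the source may bear on it.

Working notes on the series: in a functional assay on HSC-4 cells (Homo sapiens) for cytotoxicity, with a stated time of 24 h (a lower number here means that less compound is tolerated, a higher number that more compound is tolerated), compound 1 (`O=C1/C(=C/c2ccccc2)CCC/C1=C\c1ccccc1[N+](=O)[O-]`) gives 3200 nM and compound 2 (`O=C1/C(=C/c2ccc(F)cc2)CCC/C1=C\c1cccc([N+](=O)[O-])c1`) gives 2500 nM as the only two measured values. Compound 2 has only compound 1 for comparison, and the two values lie within the scatter of each other. Among the compounds with values here, these two compounds differ in more than one place, so no single-change step is available from them. Compound 3 (`CN(C)c1ccc(/C=C2\CCC/C(=C\c3cccc([N+](=O)[O-])c3)C2=O)cc1`) follows from compound 2 by one change (dimethylamino in place of fluoro on an aromatic carbon), with dimethylamino in place of fluoro on an aromatic carbon, para to a large group. Within the data shown here, no measured step covers this change, so no shift beyond the scatter is expected in this assay, and neither direction is favoured. The estimated step of no change at the digits printed from compound 2 to compound 3 (within the scatter) is expected to stay within the scatter. Compound 3 is expected at 2500 nM (estimated range 800 nM to 8000 nM).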

Compound 3, half-maximal cytotoxic concentration: 71000 nM
Compound 3: the middle estimate sits 28-fold (1.45 log units) below what was measured; measured number outside the range, above it.
By their numbers in this assay, from the lowest: compounds 2 and 1 (each within the scatter of the next); then compound 3.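

In this assay, the aromatic carbon para to a large group proves sensitive to what it carries: dimethylamino in place of fluoro gives a 28-fold higher number from compound 2 to compound 3 (1.45 log units; beyond the scatter), a large step beyond the scatter, towards more compound being tolerated. Within the data shown here, compound 1 and compound 2 differ in more than one place and gave no single-change step, so this is the first reading of any one position. Nothing available bears on the reason for the size of this step.

A single step does not show whether the shift tracks the loss of fluoro or the entry of dimethylamino, and a hydrogen, a methoxy group, a primary amine or a carboxylic acid at this place would separate the two. From the compounds shown here alone, whether the same change gives a similar step on the core of compound 1 also remains open.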